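Shortening a Pentyl Chain on a Phenyl-Alkynyl Uracil

The source may hold more compounds than are shown below. What is called first, only, known or untested is meant among the compounds shown, and "the series" means these compounds.

Measured compounds:
Compound 1 `CCCCCCC#Cc1cn(C/C=C/CN2C(=O)c3ccccc3C2=O)c(=O)[nH]c1=O`: 32000 nM
Compound 2 `CCCCCCCCC#Cc1cn(C/C=C/CN2C(=O)c3ccccc3C2=O)c(=O)[nH]c1=O`: 87000 nM
Compound 3 `CCCCCc1ccc(C#Cc2cn(C/C=C/CN3C(=O)c4ccccc4C3=O)c(=O)[nH]c2=O)cc1`: 30000 nM

These three share one core and differ only in the group on the triple-bonded carbon. In a functional assay on SW-620 cells (Homo sapiens) for antiproliferative activity, read by MTT assay, with a stated time of 3 days (a lower number here means a stronger inhibitor, a higher number a weaker inhibitor), compound 3 gives 30000 nM, the lowest of the three numbers; still, the step of a 1.1-fold lower number from compound 1 to compound 3 (0.03 log units; within the scatter) shows that compound 1 and compound 3 cannot be told apart, whereas the step of a 2.9-fold lower number from compound 2 to compound 3 (0.46 log units; beyond the scatter) is beyond the scatter.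

Compound 4 `CCCCc1ccc(C#Cc2cn(C/C=C/CN3C(=O)c4ccccc4C3=O)c(=O)[nH]c2=O)cc1` differs from compound 3 by hydrogen in place of methyl on a saturated chain carbon, four bonds along the chain from an aromatic carbon. Among the compounds with values here, no measured step removes a carbon from a chain at this place. The nearest guide is the step of a 2.7-fold higher number from compound 1 to compound 2 (0.43 log units; beyond the scatter), where lengthening a chain raised the number modestly; by that reading, shortening a chain might lower it slightly, or change nothing beyond the scatter.

The expected step is therefore small, a 1.2-fold lower number from compound 3 to compound 4 (0.08 log units; within the scatter), and compound 4 is estimated at 25000 nM, with a range from 10000 nM to 60000 nM.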

Compound 4, half-maximal inhibitory concentration: > 100000 nM
Compound 4 ended at the assay's limit (the forecaster's own chance of this, stated with the estimate: 5%); middle value at least 4.0-fold (0.60 log units) from the limit.
By their numbers in this assay, from the lowest: compounds 3 and 1 (each within the scatter of the next); then compound 2. At a limit, above all of these: compound 4.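

Here the loss of a single methyl, with hydrogen in its place on a saturated chain carbon, gives an at least 3.3-fold higher number from compound 3 to compound 4 (0.52 log units; beyond the scatter), so this position is sensitive to one carbon, and shortening the chain raises the number just as lengthening hexyl to octyl did. Where 4-pentylphenyl and hexyl could not be told apart, 4-butylphenyl gives an at least 3.1-fold higher number from compound 1 to compound 4 (0.49 log units; beyond the scatter), while against octyl it gives an at least 1.1-fold higher number from compound 2 to compound 4 (0.06 log units; that floor lies within the scatter), a floor that does not separate the two. In this assay compound 4 gives > 100000 nM, which is a limit of the assay and not a number: the limit of > 100000 nM in this assay, at which 1 of the 4 values shown sits.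

On these data alone, how large the step from compound 3 to compound 4 really is stays open. The compounds shown also do not say how a propyl or hexyl chain on the phenyl, or an amine at the chain end, would read.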